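The source may report more compounds than this note shows. Statements on the series, on what has been measured and on what is new or still open speak of the compounds shown alone.

In a functional assay on HCT-116 cells (Homo sapiens) for antiproliferative activity, read by CCK-8 assay, with a stated time of 72 h (on this read-out higher numbers stand for weaker inhibition and lower numbers for stronger inhibition), three compounds built on one shared core have been measured. Compound 1 (`Nc1ccccc1NC(=O)c1ccc(COc2ccc(Cl)cc2)cc1`) stands at 17300 nM while compound 2 (`Nc1ccccc1NC(=O)c1ccc(COc2ccccc2)cc1`) stands at 4890 nM and compound 3 (`Nc1ccccc1NC(=O)c1ccc(COc2ccc(F)cc2)cc1`) stands at 3860 nM on this measure. The comparison with the hydrogen compound is a 1.3-fold lower number from compound 2 to compound 3 (0.10 log units; within the scatter) and so those two sit level, while a 4.5-fold lower number from compound 1 to compound 3 (0.65 log units; beyond the scatter) sets the chloro compound clearly apart. Compound 3 thus shares the low end of this small set.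

Compound 4 (`CCCc1ccc(OCc2ccc(C(=O)Nc3ccccc3N)cc2)cc1`) differs from compound 3 at a single spot (propyl in place of fluoro on an aromatic carbon), with propyl in place of fluoro on an aromatic carbon. Among the compounds with values here, no measured step brings in propyl, so only the changes at this same spot can serve as a guide. Removing chloro gives a 3.5-fold lower number from compound 1 to compound 2 (0.55 log units; beyond the scatter) as a modest shift, whereas hydrogen and fluoro show no real difference. The only hint is that the chloro of compound 1 goes with the higher number at 17300 nM and so a modest rise is expected rather than a fall. The expected change is a 2.3-fold higher number from compound 3 to compound 4 (0.37 log units; beyond the scatter) and it remains a rough guess. For compound 4 the estimated value is 9000 nM within an expected range of 3000 nM to 27000 nM for repeat measurements.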

Compound 4, half-maximal inhibitory concentration: 3230 nM
Beside the measured number, compound 4's estimate is 2.8-fold (0.45 log units) above it; the measured number falls inside the stated range.
By their numbers in this assay, from the lowest: compounds 4, 3 and 2 (each within the scatter of the next); then compound 1.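

In this assay, putting a propyl chain where the fluoro stood brings 3 heavy atoms in place of 1 on the aromatic carbon, yet the result stays level, with a 1.2-fold lower number from compound 3 to compound 4 (0.08 log units; within the scatter). The comparison with the unsubstituted ring reads the same, with a 1.5-fold lower number from compound 2 to compound 4 (0.18 log units; within the scatter), while the chloro compound remains apart, with a 5.4-fold lower number from compound 1 to compound 4 (0.73 log units; beyond the scatter). So a group at this place, para to a large group, does not by itself go with a higher number: hydrogen, fluoro and propyl sit together, and compound 1 is the one compound that goes against this level picture, a point on which no measurement offers an explanation.

As far as these compounds go, it remains open whether a longer chain such as hexyl, or a bromo or methoxy group at this spot, would stay level with compounds 2, 3 and 4 or move toward the higher number of compound 1. From the compounds shown here alone, an amine or a carboxylic acid on the same aromatic carbon is equally open, so these four compounds say little about how the number would respond to groups of other kinds here.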